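This account rests on a few compounds, and the source may have more. Where it says the series, first, only, none or still open, it means among the compounds named here.

Two compounds have been measured so far in a functional assay on NCI-H1975 cells (Homo sapiens) for antiproliferative activity, read by CCK-8 assay, with a stated time of 72 h (on this read-out higher numbers stand for weaker inhibition of growth and lower numbers for stronger inhibition of growth), with these results:

compound 1 `CCC1C(=O)N(C)c2cnc(-n3ccc4cc(C(=O)NC)ccc43)nc2N1c1ccn(C)n1` gives 35700 nM
compound 2 `CCCNS(=O)(=O)c1ccc(Nc2ncc3c(n2)N(C2CCCC2)[C@H](CC)C(=O)N3C)cc1` gives 2100 nM

Compound 1 holds the higher of these two numbers, so it is the weaker of the pair, and its gap to compound 2 lies beyond the usual scatter. The next compound, compound 3 `CCC1C(=O)N(C)c2cnc(-n3ccc4cc(C(=O)NC5CCCC5)ccc43)nc2N1c1ccn(C)n1`, keeps the core of compound 1 and changes one group. It carries cyclopentyl in place of methyl on an amide-type nitrogen. Among the compounds with values here, no measured pair shows this change, and compound 2 differs from compound 1 in more than one place, so the data give no direct guide to its size. Compound 1 at 35700 nM is weak enough that a move towards stronger inhibition of growth seems the likelier direction, though a result within the scatter remains possible. In this assay the expected change is a moderate one (estimated as a 2.4-fold lower number from compound 1 to compound 3 (0.38 log units; beyond the scatter)) and its size is uncertain. For compound 3 the estimated value is 15000 nM with an expected range from 4000 nM to 50000 nM in this measurement.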

Compound 3, concentration for 50% growth inhibition: "not active" (no number reported)
The entry for compound 3 holds no number, so the estimate cannot be set against anything.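

In this assay, within the data shown here, compound 3 is reported as "not active" with no number, so no step from compound 1 to compound 3 can be read. No evidence at hand bears on this result. The compounds shown leave open how large an effect cyclopentyl in place of methyl on the amide-type nitrogen has on growth inhibition.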